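Replacing the furan group on the amide nitrogen

The source may hold more compounds than are shown below. What is called first, only, known or untested is meant among the compounds shown, and "the series" means these compounds.

In an ADME assay on MT4 cells (Homo sapiens) for cytotoxicity, read by MTT assay (on this read-out higher numbers stand for lower toxicity in this test and lower numbers for higher toxicity in this test), compound 1 `Cc1cc(C)cc(S(=O)(=O)c2c(C(=O)NCC(=O)NC(C)c3ccncc3)[nH]c3ccc(Cl)cc23)c1` gives 47000 nM. Compound 2 `Cc1cc(C)cc(S(=O)(=O)c2c(C(=O)NC(C)c3ccco3)[nH]c3ccc(Cl)cc23)c1` reads > 54700 nM, which is a limit of the assay and not a number. Compound 3 `Cc1cc(C)cc(S(=O)(=O)c2c(C(=O)NCC(=O)NCc3ccncn3)[nH]c3ccc(Cl)cc23)c1` shares their core and has not yet been measured.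

The change that leads to compound 3 is a group of 11 heavy atoms (7 carbon, 3 nitrogen, 1 oxygen; one six-membered aromatic ring with 2 hetero atoms) in place of a group of 7 heavy atoms (6 carbon, 1 oxygen; one five-membered aromatic ring with 1 hetero atom), on an amide-type nitrogen. The 1-(furan-2-yl)ethyl group leaves the amide-type nitrogen, and a larger group carrying a six-membered aromatic ring takes its place.

For the measured compounds named here, one measured step bears on this change: an at least 1.1-fold higher number from compound 1 to compound 2 (0.06 log units; that floor lies within the scatter). That step also took place on the amide-type nitrogen, where the same 1-(furan-2-yl)ethyl group entered and a larger group with a six-membered aromatic ring left. The new change therefore runs in the opposite direction, towards the kind of group found in compound 1, whose value of 47000 nM is the best guide available. In this assay, no step beyond the scatter is expected. The expected step is an at least 1.2-fold lower number from compound 2 to compound 3 (0.08 log units; that floor lies within the scatter). For compound 3 the estimated value is 45000 nM, with an expected range from 20000 nM to 70000 nM.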

Compound 3, half-maximal cytotoxic concentration: > 48800 nM
Compound 3: no number, only a limit; the forecaster's own chance of this, stated with the estimate: 35%; middle value at least 1.0-fold (0.03 log units) from the limit.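

On the amide-type nitrogen, the (pyrimidin-4-yl)methyl group now joins the two groups already seen, and in this assay compound 3 gives > 48800 nM, which is a limit of the assay and not a number. Putting this group in place of 1-(pyridin-4-yl)ethyl gives an at least 1.0-fold higher number from compound 1 to compound 3 (0.01 log units; that floor lies within the scatter), so swapping the pyridine-bearing group for the pyrimidine-bearing one shows no sign of a lower number, meaning no sign of higher toxicity in this test. The step from compound 2 to compound 3 cannot be read, so the furan-bearing group and the new group cannot be placed in any order.

On these data alone, what remains open is how far the true value of compound 3 lies from its limit, and so whether this change lowers toxicity in this test by more than the usual scatter. The compounds shown also leave open whether a quite different group on this nitrogen, such as one ending in a primary amine or a carboxylic acid, or a longer alkyl chain, would bring the number down clearly.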